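A few compounds are considered here, and "the series" means these few. Any claim that something is new, unique, unknown or untested is made for them only; others in the source may bear on it.

In a physicochemical assay for solubility, measured as kinetic solubility, at pH 2 (on this read-out higher numbers stand for higher solubility and lower numbers for lower solubility), compound 1 (`CC(C)C(CC1C(=O)NC(=O)N1C)c1ccc(-c2ccc3cccc(F)c3c2)[nH]c1=O`) gives 26600 nM and compound 2 (`CC(C)C(c1ccc(-c2ccc3cccc(F)c3c2)[nH]c1=O)C1SC(=O)NC1=O`) gives 11300 nM as the lower of the two numbers. Compound 3 (`C/C(=C1/OC(=O)NC1=O)C(c1ccc(-c2ccc3cccc(F)c3c2)[nH]c1=O)C(C)C`) has not been measured yet. Going from compound 2 to compound 3, the change is a group of 9 heavy atoms (5 carbon, 1 nitrogen, 3 oxygen; one five-membered non-aromatic ring with 2 hetero atoms) in place of a group of 7 heavy atoms (3 carbon, 1 nitrogen, 2 oxygen, 1 sulfur; one five-membered non-aromatic ring with 2 hetero atoms), on a saturated chain carbon bound to an aromatic carbon and a saturated chain carbon and the rest of the molecule stays the same. Among the compounds with values here, one measured step bears on this at the same chain carbon, namely a 2.4-fold lower number from compound 1 to compound 2 (0.37 log units; beyond the scatter) on swapping one ring-bearing group for another, and that gives a modest size to go by. Within the data shown here, the group entering compound 3 appears in no measured compound, so the data show no direction, and no change beyond the scatter is expected in this assay as the best guess. The estimated change is a 1.1-fold lower number from compound 2 to compound 3 (0.05 log units; within the scatter) as a central expectation. For compound 3 the estimated value is 10000 nM within an expected range from 3500 nM to 28000 nM in this measurement.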

Compound 3, solubility: 12700 nM
Beside the measured number, compound 3's estimate is 1.3-fold (0.10 log units) below it; the range from low to high includes it.
By their numbers in this assay, from the lowest: compounds 2 and 3 (each within the scatter of the next); then compound 1.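

In this assay, replacing 2,4-dioxo-1,3-thiazolidin-5-yl with the larger group on this saturated chain carbon gives a 1.1-fold higher number from compound 2 to compound 3 (0.05 log units; within the scatter) and so leaves the number effectively unchanged, even though the entering ring has oxygen where the leaving ring has sulfur and brings one more double bond outside aromatic rings. Set against the (3-methyl-2,5-dioxoimidazolidin-4-yl)methyl group, the same entering group gives a 2.1-fold lower number from compound 1 to compound 3 (0.32 log units; beyond the scatter) and thus a modest drop, so compound 2 and compound 3 now stand together, with compound 1 apart from both. No measurement available here explains these numbers.

From the compounds shown here alone, what a carboxylic acid or an amine at this chain carbon would do to the number stays open. So does the effect of a longer chain in place of these rings.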